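Cyclopentyl in place of pyridin-4-yl on the shared core

A few compounds are considered here, and "the series" means these few. Any claim that something is new, unique, unknown or untested is made for them only; others in the source may bear on it.

In an assay on isolated protein (Cavia porcellus) with Sigma non-opioid intracellular receptor 1 (Homo sapiens) as the target, read by radioligand binding (a higher number here means a weaker inhibitor, a lower number a stronger inhibitor), compound 2 `O=c1cc(-c2ccncc2)oc2ccc(OCCCCCCN3CCC(O)CC3)cc12` gives 159 nM, and compound 1 `COc1ccc(-c2cc(=O)c3cc(OCCCCCCN4CCC(O)CC4)ccc3o2)cc1` gives 254 nM; these two numbers lie within the scatter of each other. Compound 3 `O=c1cc(C2CCCC2)oc2ccc(OCCCCCCN3CCC(O)CC3)cc12` differs from compound 2 by cyclopentyl in place of pyridin-4-yl on an aromatic carbon. For the measured compounds named here, the only measured step, a 1.6-fold lower number from compound 1 to compound 2 (0.20 log units; within the scatter), exchanged one six-membered aromatic ring for another at this position and stayed within the scatter; no measured step replaces the aromatic ring with a non-aromatic one, so the direction is open. Compound 3 is therefore expected to give 320 nM in this assay, within a range from 80 nM to 1300 nM, a step of a 2.0-fold higher number from compound 2 to compound 3 (0.30 log units; within the scatter).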

Compound 3, half-maximal inhibitory concentration: 51 nM
Beside the measured number, compound 3's estimate is 6.3-fold (0.80 log units) above it; measured number outside the range, below it.
By their numbers in this assay, from the lowest: compound 3; then compounds 2 and 1 (each within the scatter of the next).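

At this position, next to the ring oxygen, replacing an aromatic ring with a non-aromatic one gives a 3.1-fold lower number from compound 2 to compound 3 (0.49 log units; beyond the scatter) and a 5.0-fold lower number from compound 1 to compound 3 (0.70 log units; beyond the scatter), both beyond the scatter. In this assay the position therefore responds to a change that the exchange of pyridin-4-yl for 4-methoxyphenyl did not reveal. Nothing available explains why cyclopentyl gives the lower number. On these data alone, whether the gain is specific to cyclopentyl remains open, since cyclohexyl and open-chain groups such as isopropyl or tert-butyl do not appear here. How a hydroxyl group or an amine on the ring would act is also unknown.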